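The source may hold more compounds than are shown below. What is called first, only, known or untested is meant among the compounds shown, and "the series" means these compounds.

Among the compounds with values here, in a functional assay (mitochondria) for inhibition, with Rattus norvegicus as the target (on this read-out lower numbers stand for stronger inhibition and higher numbers for weaker inhibition), compound 1 (`Cc1nc2cc(OC[C@H](O)CN3CCN(CC(=O)Nc4c(C)cccc4C)C[C@@H]3C)ccc2s1`) gives 200 nM as the lowest number of the three compounds measured so far. Compound 2 (`Cc1nc2cc(OC[C@@H](O)CN3C(C)CN(CC(=O)Nc4c(C)cccc4C)CC3C)ccc2s1`) gives 2500 nM and compound 3 (`Cc1cccc(C)c1NC(=O)CN1CCN(CC(O)COc2ccc3oc(-c4ccc(C(F)(F)F)cc4)nc3c2)CC1`) gives 8000 nM as clearly weaker results. Compound 4 (`Cc1nc2cc(OC[C@@H](O)CN3CCN(CC(=O)Nc4c(C)cccc4C)C[C@H]3C)ccc2s1`) has the same atoms and bonds as compound 1 but is its mirror image (the two compounds have the same atoms and bonds and differ only in configuration as drawn: 2 of 2 stereo elements differ (all stereocentres are inverted: mirror images); a stereocentre at a saturated chain carbon is drawn R in compound 1 and S in compound 4; a stereocentre at a saturated ring carbon is drawn S in compound 1 and R in compound 4). Both the stereocentre at the saturated chain carbon and the one at the saturated ring carbon are inverted. Within the data shown here, no measured pair shows what such an inversion does, so the expectation is loose. The expected step (a 3.0-fold higher number from compound 1 to compound 4 (0.48 log units; beyond the scatter)) is a moderate one towards weaker inhibition, and it could prove small. Compound 4 is estimated at 600 nM with a likely range from 150 nM to 3000 nM in this read-out.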

Compound 4, half-maximal inhibitory concentration: 10000 nM
Estimate against measurement, compound 4: 17-fold (1.22 log units) below; the whole stated range lies below it.
By their numbers in this assay, from the lowest: compound 1; then compound 2; then compounds 3 and 4 (each within the scatter of the next).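

In this assay, within the data shown here, inverting both stereocentres gives a 50-fold higher number from compound 1 to compound 4 (1.70 log units; beyond the scatter), the first measured pair to show that configuration alone can move this number by a large amount. The step can be assigned to configuration rather than to any change of atoms or bonds because of one fact: the fact that compounds 1 and 4 differ only in the configuration as drawn.

The two inversions occur together, so the compounds shown leave open how much of the step belongs to the saturated chain carbon and how much to the saturated ring carbon. Also open, from the compounds shown here alone, is how an ethyl group at the saturated ring carbon would behave in either configuration.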